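Cyclopropyl on the Amide Nitrogen, Carried to a Second Core

This account rests on a few compounds, and the source may have more. Where it says the series, first, only, none or still open, it means among the compounds named here.

Of the compounds shown here, three have been tested in a functional assay on the whole organism with Mus musculus as the target; on this read-out lower numbers stand for an effect already at smaller amounts and higher numbers for an effect only at larger amounts of compound. Compound 1 `C/C(=C\c1cccc(C(F)(F)F)c1)C(N)=O` gives 22.4 mg/kg in this assay. Compound 2 `C/C(=C\c1cccc(C(F)(F)F)c1)C(=O)NC1CC1` differs from compound 1 by cyclopropyl in place of hydrogen on an amide-type nitrogen, and in this assay compound 2 gives 24.1 mg/kg. The step of a 1.1-fold higher number from compound 1 to compound 2 (0.03 log units; within the scatter) shows that the added ring did not move the dose beyond the scatter of the measurement.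

Compound 3 `C/C(C(N)=O)=C(/C)c1ccc(Cl)cc1` is built on a different core; the difference between the two cores is not broken down here. In this assay compound 3 gives 20.9 mg/kg, a number that lies within the scatter of both compound 1 and compound 2, so no order among the three can be read from these values.

Compound 4 `C/C(C(=O)NC1CC1)=C(/C)c1ccc(Cl)cc1` has not yet been measured. It differs from compound 3 by cyclopropyl in place of hydrogen on an amide-type nitrogen. The place of this change is described in exactly the same words as for the change from compound 1 to compound 2, so it is the same change, made on the other core. Within the data shown here, since the only measured instance of it, a 1.1-fold higher number from compound 1 to compound 2 (0.03 log units; within the scatter), stayed within the scatter, the step to compound 4 is expected to be a 1.1-fold higher number from compound 3 to compound 4 (0.04 log units; within the scatter). Starting from compound 3 with its dose of 20.9 mg/kg, compound 4 is estimated to give 23 mg/kg in this assay, most likely between 12 mg/kg and 45 mg/kg.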

Compound 4, dose for half-maximal effect: 11.4 mg/kg
Compound 4: the middle estimate sits 2.0-fold (0.30 log units) above what was measured, and the stated range ends above it.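

In this assay, cyclopropyl in place of hydrogen on the amide-type nitrogen of the second core gives a 1.8-fold lower number from compound 3 to compound 4 (0.26 log units; within the scatter), so on this core too the step stays within the usual scatter of repeated measurements. Set beside the step on the first core, this result cannot be told apart from it: the same change on two cores in this assay, a 1.1-fold higher number (0.03 log units; within the scatter) from compound 1 to compound 2 and a 1.8-fold lower number (0.26 log units; within the scatter) from compound 3 to compound 4, 2.0-fold (0.30 log units) apart, within the scatter of two such steps

Among these compounds, this agrees with the change carrying over from one core to the other with no effect that can be measured, but it rests on only two pairs of compounds, so it does not show that the change behaves alike on any further core, and a small real effect on either core, or a small difference between the cores, could stay hidden in the scatter.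

The compounds shown carry only hydrogen or cyclopropyl on the amide nitrogen, so it remains open whether a larger ring such as cyclohexyl, or a longer chain such as n-butyl, would move the dose beyond the scatter on either core. They also leave open whether replacing the amide with a carboxylic acid or a nitrile would give matching results on the two cores.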